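This account rests on a few compounds, and the source may have more. Where it says the series, first, only, none or still open, it means among the compounds named here.

Among the compounds with values here, compound 2 `Nc1scc(-c2ccc(Cl)cc2)c1C(=O)c1ccc(Cl)cc1` stands lowest of the two compounds measured so far in a functional assay on CHO cells for agonist activity at adenosine receptor A1 (Homo sapiens), read by fluorescence and ERK phosphorylation, with stated times of 30 min and 1.5 h, tested at 3 uM; on this read-out lower numbers stand for a weaker effect and higher numbers for a stronger effect at the one concentration tested: compound 2 gives 50%, whereas compound 1 `Nc1scc(-c2cccc(F)c2)c1C(=O)c1ccc(Cl)cc1` gives 76%. Within the data shown here, the single measured step, a number 26 percentage points lower from compound 1 to compound 2 (beyond the scatter), separates these two. Compound 3 `Nc1scc(-c2cccc(Br)c2)c1C(=O)c1ccc(Cl)cc1` has not yet been measured in this assay. It differs from compound 2 in one place: 3-bromophenyl in place of 4-chlorophenyl on an aromatic carbon. This change returns to a phenyl of the kind compound 1 carries, with bromine where compound 1 has fluorine, so the step from compound 1 to compound 2 bears on it in reverse. On that basis a rise from compound 2 to compound 3 is expected, of about a number 16 percentage points higher from compound 2 to compound 3 (beyond the scatter), though bromine and fluorine are not the same and this leaves room for doubt. For compound 3 in this assay a value of 66% is estimated, within 46% to 86%.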

Compound 3, a percentage reported as activity, at one concentration (the size of the read-out at that concentration, not a potency): 62%
For compound 3 the middle estimate is 4 percentage points above the measured one; measured number inside the range.
By their numbers in this assay, from the lowest: compound 2; then compound 3; then compound 1.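

In this assay, 3-bromophenyl in place of 4-chlorophenyl gives a number 12 percentage points higher from compound 2 to compound 3 (beyond the scatter), so this position on the five-membered ring can regain part of the effect lost with 4-chlorophenyl. Bromo in place of fluoro gives a number 14 percentage points lower from compound 1 to compound 3 (beyond the scatter), which shows that the choice of halogen on the phenyl also changes the read-out, and that the 3-bromophenyl group does not match the 3-fluorophenyl group. Nothing measured here accounts for these differences.

Going by these compounds, whether the lower number of compound 2 goes with the chlorine or with its place on the phenyl stays open, as compound 2 differs from compound 1 and compound 3 in both. Also open, on these data alone, is how a plain phenyl, or a phenyl bearing a methoxy group or an amine, would compare with these halogen-bearing groups.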